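Series notes: dropping the methoxy from compound 2

The source may report more compounds than this note shows. Statements on the series, on what has been measured and on what is new or still open speak of the compounds shown alone.

Measured so far in a functional assay on HCT-116 cells (Homo sapiens) for inhibition, read by sulforhodamine B assay, with a stated time of 48 h, tested at 50 uM; a higher number here means more inhibition of growth at the concentration tested, a lower number less inhibition of growth:
compound 1, `O=C1C(=O)N(CCCCCn2cc(COc3cc(=O)oc4ccccc34)nn2)c2ccc(F)cc21`: 59%
compound 2, `COc1ccc2c(c1)C(=O)C(=O)N2CCCn1cc(COc2cc(=O)oc3ccccc23)nn1`: 52%

Compound 2 stands at 52% in this assay. Compound 1 stands at 59%, and the gap between the two numbers is within the scatter, so the two cannot be told apart on these data. The two compounds also differ in more than one place, so no single change is isolated by them.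

Compound 3, `O=C1C(=O)N(CCCn2cc(COc3cc(=O)oc4ccccc34)nn2)c2ccccc21`, differs from compound 2 in one place: hydrogen in place of methoxy on an aromatic carbon. Among the compounds with values here, no pair of measured compounds shows what this change alone does, and the two numbers in hand give no trend to lean on. The expected step of a number 2 percentage points lower from compound 2 to compound 3 (within the scatter) is therefore small, with no clear direction and not beyond the scatter. Compound 3 is estimated at 50% in this assay, with a range from 35% to 65%.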

Compound 3, percent growth inhibition at one concentration: 79%
Compound 3: middle estimate off by 29 percentage points, on the low side; measured number above the stated range.
By their numbers in this assay, from the lowest: compounds 2 and 1 (each within the scatter of the next); then compound 3.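

Hydrogen in place of methoxy on an aromatic carbon gives a number 27 percentage points higher from compound 2 to compound 3 (beyond the scatter) in this assay, the first step in the series that isolates a single change. This position, meta to a fused ring and para to a fused ring, is therefore not indifferent to what it carries, and with methoxy gone, more growth inhibition is seen at the concentration tested. Nothing at hand bears on what lies behind this step.

From the compounds shown here alone, whether hydrogen itself is the best choice here stays open, since an amine or a hydroxyl at this aromatic carbon could read differently. Also open, going by these compounds, is whether the same step would appear on a longer chain, as the shared core has not been compared with and without methoxy in that setting.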